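The source may hold more compounds than are shown below. What is called first, only, known or untested is meant among the compounds shown, and "the series" means these compounds.

In an ADME assay on MRC5 cells (Homo sapiens), read by MTT assay, with a stated time of 72 h (a higher number here means a weaker inhibitor, a lower number a stronger inhibitor), three nucleosides built on a shared core were measured. Compound 1 `O=c1[nH]cnc2c1c(-c1ccco1)cn2[C@@H]1O[C@H](CO)[C@@H](O)[C@H]1O` carries a furan-2-yl group and returns only the limit of the assay, > 100000 nM. Compound 2 `O=c1[nH]cnc2c1c(-c1cc3ccccc3o1)cn2[C@@H]1O[C@H](CO)[C@@H](O)[C@H]1O` carries a 1-benzofuran-2-yl group at the same place and likewise returns only a limit, > 100000 nM. The step that the two limits leave unreadable from compound 2 to compound 1, (furan-2-yl in place of 1-benzofuran-2-yl on an aromatic carbon), therefore cannot be sized, because the limit of > 100000 nM in this assay, at which 2 of the 3 values shown sit, caps both values. Compound 3 `CNc1ncnc2c1c(-c1cc3ccccc3o1)cn2[C@@H]1O[C@H](CO)[C@@H](O)[C@H]1O` differs from compound 2 in its core, and the difference between the two cores is not broken down here. Compound 3 is the only one of the three to give a number, 75300 nM. Compound 4 `CNc1ncnc2c1c(-c1ccco1)cn2[C@@H]1O[C@H](CO)[C@@H](O)[C@H]1O` has not been measured; it stands to compound 3 as compound 1 stands to compound 2, the same change, (furan-2-yl in place of 1-benzofuran-2-yl on an aromatic carbon). For the measured compounds named here, compound 3 gives a weak number, 75300 nM, and the one measured instance of this change stayed unreadable. For compound 4 a step of a 1.3-fold higher number from compound 3 to compound 4 (0.12 log units; within the scatter) is expected, small in either direction. Compound 4 is thus estimated at 100000 nM, most likely between 40000 nM and 300000 nM, with a fair chance that only a limit is reported.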

Compound 4, half-maximal inhibitory concentration: 90800 nM
For compound 4 the middle estimate is 1.1-fold (0.04 log units) above the measured one, within the range that was stated.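

In this assay, replacing 1-benzofuran-2-yl with furan-2-yl on the core of compound 3 gives a 1.2-fold higher number from compound 3 to compound 4 (0.08 log units; within the scatter), so on this core the change leaves the number where it was, within the usual scatter. The same change on the other core, from compound 2 to compound 1, cannot be read, because both compounds give a limit and not a number: the limit of > 100000 nM in this assay, at which 2 of the 4 values shown sit. The series therefore holds a single readable instance of this change on a single core, which shows that the step is small there but does not show that it carries over to the other core.

The compounds shown leave open whether another group on this aromatic carbon, such as an amine, a carboxylic acid or a longer chain, would give a step beyond the scatter on the core of compound 3. They also leave open whether any such group would bring a readable number on the core of compound 1.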